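The source may hold more compounds than are shown below. What is called first, only, known or untested is meant among the compounds shown, and "the series" means these compounds.

Measured compounds in a physicochemical assay for lipophilicity, read by HPLC, in phosphate buffer, measured as octanol-water partition, at pH 7.4; on this read-out lower numbers stand for lower lipophilicity and higher numbers for higher lipophilicity:
compound 1 `CCOC(=O)c1ccc(/N=N/N(C)C(=O)[C@H](C)NC(C)=O)cc1`, 2.52
compound 2 `CCC(=O)N[C@@H](C)C(=O)N(C)/N=N/c1ccc(C#N)cc1`, 1.87
compound 3 `CC(=O)NCC(=O)N(C)/N=N/c1ccc(C#N)cc1`, 1.1

Compound 2 stands second highest of the three numbers in this assay: compound 1 sits higher, compound 3 lower, both gaps beyond the scatter. Compound 4 `CCCC(=O)N[C@@H](C)C(=O)N(C)/N=N/c1ccc(C#N)cc1` differs from compound 2 by methyl in place of hydrogen on a saturated chain carbon, two bonds along the chain from a carbonyl carbon, extending propanoyl to propylcarbonyl. Among the compounds with values here, the one measured step that bears on it is a number 0.77 log units lower from compound 2 to compound 3 (beyond the scatter), where trimming the acyl group and the side chain together lowered the number moderately. Adding one chain carbon is expected to move this assay upward, a small but real step. The expected step is a number 0.43 log units higher from compound 2 to compound 4 (beyond the scatter). Compound 4 is therefore estimated at 2.3, with a range from 2 to 2.6.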

Compound 4, partition coefficient: 2.28
Beside the measured number, compound 4's estimate is 0.02 log units above it; the range from low to high includes it.
By their numbers in this assay, from the lowest: compound 3; then compound 2; then compounds 4 and 1 (each within the scatter of the next).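

In this assay, methyl in place of hydrogen on this saturated chain carbon gives a number 0.41 log units higher from compound 2 to compound 4 (beyond the scatter) and so isolates a single change at this position. The earlier a number 0.77 log units lower from compound 2 to compound 3 (beyond the scatter) replaced the whole group on the carbonyl carbon, so it could not show what this one chain carbon contributes. No measured evidence accounts for the size of the new step.

From the compounds shown here alone, whether a longer chain or a terminal amine at this position would continue the upward move remains open. Also open, going by these compounds, is whether the same change gives a similar step on compound 1 or compound 3.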